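Aryl groups on the shared core and mGlu5 modulation

The source may hold more compounds than are shown below. What is called first, only, known or untested is meant among the compounds shown, and "the series" means these compounds.

Compound 1 `CC(C)Cc1noc(C2CCc3c(nnn3C(C)(C)C)C2)n1` gives 1000 nM; compound 2 `CC(C)(C)n1nnc2c1CCC(c1nc(C3CCCCC3)no1)C2` gives 200 nM; compound 3 `CC(C)(C)n1nnc2c1CCC(c1nc(Cc3ccc(F)cc3)no1)C2` gives 20 nM, all in a functional assay on U2OS cells for positive allosteric modulation of metabotropic glutamate receptor 5 (Homo sapiens), read by calcium flux, in the presence of a further agent that is not named here; a lower number here means that less compound is needed, a higher number that more compound is needed for the effect.

Compound 3 holds the lowest number of the three, beyond the scatter against both compound 2 and compound 1. Compound 4 `CC(C)(C)n1nnc2c1CCC(c1nc(-c3ccc(C#N)cc3)no1)C2` differs from it by 4-cyanophenyl in place of 4-fluorobenzyl on an aromatic carbon. Going by the values given here, no measured step exchanges a saturated-chain group for an aryl bound directly to the ring; the steps of a 50-fold lower number from compound 1 to compound 3 (1.70 log units; beyond the scatter) and a 10-fold lower number from compound 2 to compound 3 (1.00 log units; beyond the scatter) only show that the 4-fluorobenzyl group gives a markedly lower number than the alkyl groups. Compound 4 is therefore expected to give a somewhat higher number than compound 3, a 3.0-fold higher number from compound 3 to compound 4 (0.48 log units; beyond the scatter), with wide uncertainty. The estimate for compound 4 in this assay is 60 nM, between 15 nM and 300 nM.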

Compound 4, half-maximal effective concentration: 79.4 nM
The estimate for compound 4 lay 1.3-fold (0.12 log units) below the measured number; the measured number falls inside the stated range.
By their numbers in this assay, from the lowest: compound 3; then compound 4; then compound 2; then compound 1.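

Going by these compounds alone, with 4-cyanophenyl, an aryl group bound directly to this aromatic carbon is seen for the first time, and it gives lower numbers than isobutyl, with a 13-fold lower number from compound 1 to compound 4 (1.10 log units; beyond the scatter), and cyclohexyl, with a 2.5-fold lower number from compound 2 to compound 4 (0.40 log units; beyond the scatter). It does not match 4-fluorobenzyl, however, with a 4.0-fold higher number from compound 3 to compound 4 (0.60 log units; beyond the scatter), so among these compounds, a six-membered aromatic ring at this place does not alone give the lowest number.

From the compounds shown here alone, how a phenyl, a 4-fluorophenyl or a 4-cyanobenzyl would compare here remains open, so the last step cannot be divided between the nitrile, the fluorine and the connecting carbon. Nothing shown accounts for these differences.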